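The compounds below may be only part of what the source reports. "The series", "measured", "known", "first", "only" and "open" are said of these compounds alone.

Measured so far:
Compound 1 `CCN(CC)CN1C(=O)/C(=N/NC(N)=S)c2ccccc21` gives in an ADME assay on HEL cells (Homo sapiens) for cytotoxicity (a lower number here means that less compound is tolerated, a higher number that more compound is tolerated), the value > 100000 nM, which is a limit of the assay.
Compound 2 `CCN(CC)CN1C(=O)/C(=N/NC(=S)Nc2ccc(Cl)cc2)c2cc(Cl)ccc21` gives in this assay the value 100000 nM.
Compound 3 `CCN(CC)CN1C(=O)/C(=N/NC(=S)Nc2ccc(Cl)cc2)c2ccccc21` gives in this assay the value 100000 nM.

Compound 2 stands level with compound 3 at the digits shown; the step of no change at the digits printed from compound 2 to compound 3 (within the scatter) lies within the scatter. The value of compound 1 is a limit only (the limit of > 100000 nM in this assay, at which 1 of the 3 values shown sits), so the step of a number no higher from compound 1 to compound 3 (the limit leaves the size open) has no readable size.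

Compound 4 `CCN(CC)CN1C(=O)/C(=N/NC(=S)Nc2ccc(OC)cc2)c2cc(Cl)ccc21` differs from compound 2 in one place: methoxy in place of chloro on an aromatic carbon. Going by the values given here, the measured step that comes nearest is the one from compound 2 to compound 3, where a chloro on an aromatic carbon was exchanged for hydrogen with no change in this assay beyond the scatter. The step from compound 1 to compound 3 put a 4-chlorophenyl onto an amide-type nitrogen, but its size is left open by the limit. Among the compounds with values here, with the only readable step at the same kind of position showing no change, compound 4 is expected to stay where compound 2 stands, a step of no change at the digits printed from compound 2 to compound 4 (within the scatter) of no size beyond the scatter. Compound 4 is therefore estimated at 100000 nM, within 50000 nM to 200000 nM.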

Compound 4, minimum cytotoxic concentration: 100000 nM
Beside the measured number, compound 4's estimate shows no gap at the digits printed, within the range that was stated.
By their numbers in this assay, from the lowest: compounds 2, 3 and 4 (each within the scatter of the next).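

In this assay, methoxy in place of chloro on an aromatic carbon of the six-membered ring, para to a large group, gives no change at the digits printed from compound 2 to compound 4 (within the scatter). Going by these compounds alone, this is the first readable step at this position on the 4-chlorophenyl group, since the only readable step among the earlier compounds removed a chloro from the shared core and left this group untouched. The exchange of 4-chlorophenyl for 4-methoxyphenyl, which puts an oxygen and a carbon where a chlorine stood, therefore leaves the number within the scatter, so this position accepts at least these two groups alike in this one pair.

What the compounds shown leave open is whether an amine or a carboxylic acid at this position, or a longer chain in place of the methyl of the methoxy, would also leave the number within the scatter. The step from the unsubstituted thiosemicarbazone end of compound 1 cannot be read, so what the aryl group itself contributes stays unknown, and the value of compound 1 is a limit only: the limit of > 100000 nM in this assay, at which 1 of the 4 values shown sits.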